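The compounds below may be only part of what the source reports. "The series", "measured", "known", "first", "only" and "open" are said of these compounds alone.

Three compounds have so far been tested in a functional assay on the whole organism with Mus musculus as the target, at a dose of 100 mg/kg by the intraperitoneal route; on this read-out higher numbers stand for more inhibition at the one dose given (going by the name of the read-out) and lower numbers for less inhibition:

compound 1 `NC(=O)/C=C1\CCc2cc(Cl)ccc21` gives 0%;
compound 2 `O=C(/C=C1/CCc2ccc(Cl)cc21)NC1CC1` gives 0%;
compound 3 `O=C(/C=C1\CCc2ccc(F)cc21)NCc1ccccc1` gives 17%.

Compound 3 stands highest of the three, and compound 1 and compound 2 both lie below it by a margin beyond the usual scatter. Compound 4 `CNC(=O)/C=C1\CCc2ccc(F)cc21` has not yet been measured in this assay. It differs from compound 3 in a single place: hydrogen in place of phenyl on a saturated chain carbon bound to an amide-type nitrogen. Among the measured compounds shown here, no pair of measured compounds shows this exact change, so the expectation rests on the numbers alone. Compound 1 gives 0% and compound 2 gives 0%, neither showing any inhibition. On that basis the step of a number 12 percentage points lower from compound 3 to compound 4 (beyond the scatter) is expected to run downward, likely beyond the scatter. Compound 4 is therefore estimated at 5%, within a range from 0% to 20%.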

Compound 4, a percentage reported as inhibition, in the whole organism at one dose (the size of the read-out at that dose, not a potency): 50%
Beside the measured number, compound 4's estimate is 45 percentage points below it, and the stated range ends below it.
By their numbers in this assay, from the lowest: compounds 1 and 2 (each within the scatter of the next); then compound 3; then compound 4.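

In this assay, cutting benzyl back to methyl gives a number 33 percentage points higher from compound 3 to compound 4 (beyond the scatter). This position therefore matters for the read-out, and in this pair the phenyl is not needed for inhibition, since the smaller group gives the higher number. No measurement at hand offers a reason for the rise. The compounds shown leave open whether ethyl or a longer chain would hold this level, and how a chain ending in an amine or a carboxylic acid would fare.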